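This account rests on a few compounds, and the source may have more. Where it says the series, first, only, none or still open, it means among the compounds named here.

Of the compounds shown here, two have been measured in an assay on isolated protein for inhibition of histone acetyltransferase p300 (Homo sapiens), with a stated time of 60 min; a higher number here means a weaker inhibitor, a lower number a stronger inhibitor. Compound 1 `O=C(Nc1ccc2[nH]c(=O)[nH]c2c1)[C@H]1CCCN1C(=O)C1(c2cccc(Cl)c2)CCCC1` gives 0.398 nM, the lowest of the two numbers, and the gap to compound 2 `COc1ccc(NC(=O)[C@H]2CCCN2C(=O)C2(c3ccc(Cl)cc3)CCC2)cc1`, which in this assay gives 10 nM, lies beyond the usual scatter. Compound 3 `O=C(Nc1ccc(O)cc1)[C@H]1CCCN1C(=O)C1(c2cccc(Cl)c2)CCCC1` is compound 1 with one change on the amide-type nitrogen: a group of 7 heavy atoms (6 carbon, 1 oxygen; one six-membered aromatic ring of carbon only) in place of a group of 10 heavy atoms (7 carbon, 2 nitrogen, 1 oxygen; one five-membered aromatic ring with 2 hetero atoms, one six-membered aromatic ring of carbon only), on an amide-type nitrogen. Going by the values given here, no measured pair shows a change of this kind, so the expectation rests on these two numbers alone: a weakening is expected, a step in this assay of a 20-fold higher number from compound 1 to compound 3 (1.30 log units; beyond the scatter) that goes beyond the scatter. Compound 3 is therefore estimated at 8 nM, with a range from 1.5 nM to 40 nM.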

Compound 3, half-maximal inhibitory concentration: 0.631 nM
Estimate against measurement, compound 3: 13-fold (1.10 log units) above; the measured number lies below the stated range.
By their numbers in this assay, from the lowest: compounds 1 and 3 (each within the scatter of the next); then compound 2.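

On the amide-type nitrogen of the shared core, the larger group of compound 1, with its five-membered and six-membered aromatic rings, can give way to the single ring of 4-hydroxyphenyl with only a 1.6-fold higher number from compound 1 to compound 3 (0.20 log units; within the scatter). The five-membered ring is therefore not required for a low number at this position. Nothing measured explains why the two compounds lie so close.

Still open, from the compounds shown here alone, is whether the hydroxyl of 4-hydroxyphenyl matters, which a plain phenyl or a 4-aminophenyl on the same nitrogen would test. Compound 2 differs from compound 3 in more than one place and gives no answer.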